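The source may hold more compounds than are shown below. What is called first, only, known or untested is meant among the compounds shown, and "the series" means these compounds.

Compound 1 `COc1cc(C(c2ccc(O)c(OC)c2)[C@@H](C)[C@H](C)CO)ccc1O` carries the shared core with a 2-(hydroxymethyl)-1-methylpropyl group on the saturated chain carbon bound to two aromatic carbons. In a functional assay on HL-60 cells (Homo sapiens) for cytotoxicity, read by WST assay, with a stated time of 48 h (a higher number here means a weaker inhibitor, a lower number a stronger inhibitor), compound 1 gives only a limit, > 100000 nM. Its mirror image, compound 3 `COc1cc(C(c2ccc(O)c(OC)c2)[C@H](C)[C@@H](C)CO)ccc1O`, also reaches only a limit, > 100000 nM. Compound 2 `COC[C@@H](C(C)C)C(c1ccc(O)c(OC)c1)c1ccc(O)c(OC)c1` gives 54000 nM. The step of an at least 1.8-fold lower number from compound 1 to compound 2 (0.26 log units; that floor lies within the scatter) swaps the side chain, while the step that the two limits leave unreadable from compound 1 to compound 3 cannot be sized because of the limit of > 100000 nM in this assay, at which 2 of the 3 values shown sit, together with the fact that compounds 1 and 3 differ only in the configuration as drawn. Compound 4 `COc1cc(C(c2ccc(O)c(OC)c2)[C@H](C)[C@H](C)CO)ccc1O` differs from compound 1 by the two compounds have the same atoms and bonds and differ only in configuration as drawn: 1 of 2 stereo elements differ; a stereocentre at a saturated chain carbon is drawn R in compound 1 and S in compound 4. Within the data shown here, only the step from compound 1 to compound 3 concerns configuration, and it gives no readable size, so no step beyond the scatter is expected in this assay. Compound 4 is therefore expected near 100000 nM, between 40000 nM and 300000 nM, which means a number no higher from compound 1 to compound 4 (the limit leaves the size open).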

Compound 4, half-maximal inhibitory concentration: > 100000 nM
Compound 4 was reported as a limit (the forecaster's own chance of this, stated with the estimate: 65%); the middle value sits exactly at the limit.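

Changing one stereocentre, like changing both, leaves the result in this assay at a limit, so the steps from compound 1 and from compound 3 to compound 4 cannot be read: the limit of > 100000 nM in this assay, at which 3 of the 4 values shown sit.

Among these compounds, the one readable step, an at least 1.8-fold higher number from compound 2 to compound 4 (0.26 log units; that floor lies within the scatter), brings in 2-(hydroxymethyl)-1-methylpropyl in place of 1-(methoxymethyl)-2-methylpropyl, so it does not show that this change matters.

On these data alone, whether configuration in this side chain affects the number at all stays open. Also open, as far as these compounds go, is what a side chain carrying an amine, or a longer chain, would give.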